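This account rests on a few compounds, and the source may have more. Where it says the series, first, only, none or still open, it means among the compounds named here.

In a functional assay on CCRF-CEM cells (Homo sapiens) for antiproliferative activity, read by cell counting, with a stated time of 2 days (on this read-out lower numbers stand for stronger inhibition and higher numbers for weaker inhibition), compound 1 `COc1cc(C(=O)c2sc(N)nc2N)cc(OC)c1OC` with a plain amino group on the shared core gives 42000 nM as its reading. Compound 2 `CCN(CC)c1nc(N)c(C(=O)c2cc(OC)c(OC)c(OC)c2)s1` with diethylamino in that place gives 78000 nM as its reading, and compound 3 `CCCCN(C)c1nc(N)c(C(=O)c2cc(OC)c(OC)c(OC)c2)s1` with butyl(methyl)amino gives 42000 nM as its reading. Compound 3 thus stands level with compound 1 and within the scatter of compound 2.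

The change to compound 4 `COc1cc(C(=O)c2sc(N(C)Cc3ccccc3)nc2N)cc(OC)c1OC` is phenyl in place of propyl on a saturated chain carbon bound to a nitrogen on an aromatic ring, turning butyl(methyl)amino into benzyl(methyl)amino (phenyl in place of propyl on a saturated chain carbon bound to a nitrogen on an aromatic ring). The measured steps that bear on this swap the same amino group (a 1.9-fold higher number from compound 1 to compound 2 (0.27 log units; within the scatter)) and (no change at the digits printed from compound 1 to compound 3 (within the scatter)) and (a 1.9-fold lower number from compound 2 to compound 3 (0.27 log units; within the scatter)), and all of them stay within the scatter. None of them brings in a ring, which leaves the outcome fairly open. No step beyond the scatter is therefore expected in this assay in either direction. The expected step is small (a 1.4-fold lower number from compound 3 to compound 4 (0.15 log units; within the scatter)). Compound 4 is estimated at 30000 nM with an expected range from 8000 nM to 80000 nM as its bounds.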

Compound 4, half-maximal inhibitory concentration: > 200000 nM
Compound 4 ended at the assay's limit; the forecaster's own chance of this, stated with the estimate: 10%; at least 6.6-fold (0.82 log units) between middle value and limit.
By their numbers in this assay, from the lowest: compounds 1, 3 and 2 (each within the scatter of the next). At a limit, above all of these: compound 4.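

The reading of compound 4 is a limit of the assay and not a number: the limit of > 200000 nM in this assay, at which 1 of the 4 values shown sits. Amino, diethylamino and butyl(methyl)amino on the shared core all gave readings within the scatter of one another, whereas phenyl in place of propyl on a saturated chain carbon bound to a nitrogen on an aromatic ring gives the first step beyond the scatter, an at least 4.7-fold higher number from compound 3 to compound 4 (0.67 log units; beyond the scatter). For the compounds shown here, the other two comparisons agree, with an at least 2.5-fold higher number from compound 2 to compound 4 (0.40 log units; beyond the scatter) and an at least 4.7-fold higher number from compound 1 to compound 4 (0.67 log units; beyond the scatter), so this position does not accept every group equally, and the one group here that brings in a ring gives the weakest result.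

From the compounds shown here alone, what remains open is whether this goes with the aromatic ring itself or with the larger group. A cyclohexyl ring or a longer chain such as hexyl in the same place would help separate the two.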